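Amino for Chloro on a Fused Two-Ring Core

The source may report more compounds than this note shows. Statements on the series, on what has been measured and on what is new or still open speak of the compounds shown alone.

Three compounds have been measured in a functional assay on LS174T cells (Homo sapiens) for inhibition, with a stated time of 4 days, tested at 1 uM; on this read-out higher numbers stand for a stronger effect at the one concentration tested and lower numbers for a weaker effect:
- compound 1 `O=C1CCCCN1c1ccc(C#Cc2c(F)cccc2F)cc1` gives 6.4%
- compound 2 `Cc1ccc(C)n1-c1ccc(C#Cc2c(F)cccc2F)cc1` gives 20.9%
- compound 3 `Fc1cccc(F)c1C#Cc1ccc2nccc(Cl)c2c1` gives 43.8%

On these numbers compound 3 stands highest of the three; its nearest neighbour is compound 2, and compound 1 lies furthest away. Within the data shown here, the only single-site step measured so far is a number 14.5 percentage points higher from compound 1 to compound 2 (beyond the scatter), a change on the core that compound 4 does not share. Compound 4 `Nc1ccnc2ccc(C#Cc3c(F)cccc3F)cc12` differs from compound 3 in one place: amino in place of chloro on an aromatic carbon. Among the measured compounds shown here, no measured step touches this position, so there is nothing to lean on beyond the value of compound 3 itself. The step from compound 3 to compound 4 is therefore expected to be a number 0.2 percentage points higher from compound 3 to compound 4 (within the scatter), nothing beyond the scatter. Compound 4 is estimated at 44%, with a range from 18% to 70%.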

Compound 4, a percentage reported as inhibition, at one concentration (the size of the read-out at that concentration, not a potency): 66.2%
Compound 4: middle estimate off by 22.2 percentage points, on the low side; measured number inside the range.
By their numbers in this assay, from the lowest: compound 1; then compound 2; then compound 3; then compound 4.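

In this assay, amino in place of chloro on this aromatic carbon, opposite the ring nitrogen, gives a number 22.4 percentage points higher from compound 3 to compound 4 (beyond the scatter) and shows that the read-out responds to a change of a single atom at this position. The swap adds a hydrogen-bond donor and a hydrogen-bond acceptor by count, but nothing available links the rise to these or to any other cause. Going by these compounds, it remains open whether a methylamino, dimethylamino or hydroxyl group at this position would match amino. On these data alone, whether the same swap would raise the read-out on another core also remains open.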